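Methyl on the chain carbon of compound 1

The compounds below may be only part of what the source reports. "The series", "measured", "known", "first", "only" and "open" are said of these compounds alone.

In a physicochemical assay for lipophilicity, read by HPLC (on this read-out lower numbers stand for lower lipophilicity and higher numbers for higher lipophilicity), compound 1 `O=S(=O)(CS(=O)(=O)C(F)(F)F)c1ccc(OC(F)(F)F)cc1` gives 2.2, compound 2 `CC(C)(C)c1ccc(S(=O)(=O)CS(=O)(=O)C(F)(F)F)cc1` gives 2.4 and compound 3 `O=S(=O)(CS(=O)(=O)C(F)(F)F)c1ccc(C(F)(F)F)cc1` gives 1. Compound 1 therefore belongs to the upper pair of these three, with no separation beyond the scatter from its nearest neighbour and a large gap to the lowest.

Compound 4 `CC(S(=O)(=O)c1ccc(OC(F)(F)F)cc1)S(=O)(=O)C(F)(F)F` is the next to be read. It differs from compound 1 by methyl in place of hydrogen on a saturated chain carbon bound to two sulfonyl sulfurs.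

Going by the values given here, no measured step involves this chain carbon. All three lie on an aromatic carbon, so they offer only a loose guide to the range of possible movement: a number 0.20 log units higher from compound 1 to compound 2 (within the scatter), a number 1.20 log units lower from compound 1 to compound 3 (beyond the scatter) and a number 1.40 log units lower from compound 2 to compound 3 (beyond the scatter). Among the compounds with values here, with a single added carbon and no direct precedent, a small upward shift in this assay is expected, and the estimated step is a number 0.40 log units higher from compound 1 to compound 4 (beyond the scatter). For compound 4 the estimated value is 2.6, with an expected range from 2.1 to 3.1.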

Compound 4, partition coefficient: 3
The estimate for compound 4 lay 0.40 log units below the measured number, and the stated range covers the measured number.
By their numbers in this assay, from the lowest: compound 3; then compounds 1 and 2 (each within the scatter of the next); then compound 4.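

The chain carbon bound to two sulfonyl sulfurs is a position that responds in this series: methyl in place of hydrogen there gives a number 0.80 log units higher from compound 1 to compound 4 (beyond the scatter) in this assay. One added carbon on the chain is thus enough to shift the read-out, whereas all the other steps shown lie on an aromatic carbon. Nothing available bears on why the step has this size.

As far as these compounds go, this reading rests on a single pair, so it remains open whether the same step would appear with tert-butyl or trifluoromethyl on the aromatic carbon, as in the cores of compound 2 and compound 3. Also open, from the compounds shown here alone, is how the read-out would respond to a second methyl on the same chain carbon, a longer chain such as ethyl, or fluorine there.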